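Benzoyl to naphthoyl ester: cytotoxicity on the shared core

The source may hold more compounds than are shown below. What is called first, only, known or untested is meant among the compounds shown, and "the series" means these compounds.

compound 1 `O=C(OC1CCC(CN2CCN(c3cc(=O)c4cc(C(F)(F)F)cc([N+](=O)[O-])c4s3)CC2)CC1)c1cccs1`: > 64 ug/mL
compound 2 `O=C(OC1CCC(CN2CCN(c3cc(=O)c4cc(C(F)(F)F)cc([N+](=O)[O-])c4s3)CC2)CC1)c1ccccc1`: > 64 ug/mL

In an ADME assay on Vero cells (Chlorocebus sabaeus) for cytotoxicity, read by MTT assay, with a stated time of 48 h (a lower number here means a stronger inhibitor, a higher number a weaker inhibitor), compound 1 reaches only the limit > 64 ug/mL. Compound 2, with phenyl in place of thiophen-2-yl on a carbonyl carbon, also gives only the limit > 64 ug/mL in this assay. The step that the two limits leave unreadable from compound 1 to compound 2 therefore stays unreadable, because the limit of > 64 ug/mL in this assay, at which 2 of the 2 values shown sit, describes both values.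

Compound 3 `O=C(OC1CCC(CN2CCN(c3cc(=O)c4cc(C(F)(F)F)cc([N+](=O)[O-])c4s3)CC2)CC1)c1ccc2ccccc2c1` differs from compound 2 by naphthalen-2-yl in place of phenyl on a carbonyl carbon. No measured step sizes this change, so compound 3 is expected to stay at the limit in this assay. Its value is estimated at 80 ug/mL, between 40 ug/mL and 160 ug/mL, with an expected step that the limit leaves unreadable from compound 2 to compound 3 not beyond the scatter.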

Compound 3, half-maximal inhibitory concentration: > 64 ug/mL
Compound 3 gave a limit, no number; the forecaster's own chance of this, stated with the estimate: 75%; the middle value is on the limit's open side.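

Within the data shown here, compound 3 gives only the limit > 64 ug/mL in this assay, so no step among compound 1, compound 2 and compound 3 can be read: the limit of > 64 ug/mL in this assay, at which 3 of the 3 values shown sit.

The compounds shown leave open whether thiophen-2-yl, phenyl and naphthalen-2-yl differ at all in this assay.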